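Methyl for fluoro on the core: compound 4 expected

The source may report more compounds than this note shows. Statements on the series, on what has been measured and on what is new or still open speak of the compounds shown alone.

Compound 1 `Cc1ccc2ncc(S(=O)(=O)c3ccc(F)c(Cl)c3)c(N3CCC(C)CC3)c2c1`: 93%
Compound 2 `Cc1ccc2ncc(S(=O)(=O)c3ccc(Cl)cc3)c(N3CCC(C)CC3)c2c1`: 79%
Compound 3 `CC1CCN(c2c(S(=O)(=O)c3ccccc3)cnc3ccc(F)cc23)CC1`: 40%

In an assay on isolated protein for displacement of a labelled ligand from metabotropic glutamate receptor 5 (Homo sapiens), with a stated time of 60 min, tested at 1 uM (on this read-out higher numbers stand for more inhibition at the one concentration tested (going by the name of the read-out) and lower numbers for less inhibition), compound 3 gives 40%, the lowest of the three numbers; compound 2 is higher than compound 3 by a margin beyond the scatter, and compound 1 higher still. Compound 4 `Cc1ccc2ncc(S(=O)(=O)c3ccccc3)c(N3CCC(C)CC3)c2c1` is not yet measured. It differs from compound 3 by methyl in place of fluoro on an aromatic carbon. Within the data shown here, no measured step bears directly on this change: the only step, a number 14 percentage points lower from compound 1 to compound 2 (beyond the scatter), concerns the group on the sulfonyl sulfur, not the fused ring. Compounds 2 and 3 differ in two places, so their gap cannot be split. Compound 4 is therefore expected to rise by a number 20 percentage points higher from compound 3 to compound 4 (beyond the scatter), with wide uncertainty. Compound 4 is estimated at 60%, between 35% and 85%.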

Compound 4, a percentage reported as inhibition, at one concentration (the size of the read-out at that concentration, not a potency): 67%
Compound 4: the middle estimate sits 7 percentage points below what was measured; the range from low to high includes it.
By their numbers in this assay, from the lowest: compound 3; then compound 4; then compound 2; then compound 1.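

In this assay the aromatic carbon bearing fluoro in compound 3 proves sensitive to its substituent: methyl in place of fluoro gives a number 27 percentage points higher from compound 3 to compound 4 (beyond the scatter). With the methyl held fixed, hydrogen in place of chloro gives a number 12 percentage points lower from compound 2 to compound 4 (beyond the scatter), and phenyl in place of 3-chloro-4-fluorophenyl gives a number 26 percentage points lower from compound 1 to compound 4 (beyond the scatter), so both places move the number. Nothing available explains why the number is higher with methyl than with fluoro here.

Still open, from the compounds shown here alone, is how a methoxy group or a nitrile on that carbon would compare with methyl. Going by these compounds, whether chloro on the phenyl ring gives a similar step alongside fluoro on the core also remains unknown.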